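Phenyl for methyl on the ring nitrogen: compound 3

A few compounds are considered here, and "the series" means these few. Any claim that something is new, unique, unknown or untested is made for them only; others in the source may bear on it.

Measured so far in a functional assay on MKN-45 cells (Homo sapiens) for antiproliferative activity, tested at 1 uM; on this read-out higher numbers stand for more inhibition at the one concentration tested (going by the name of the read-out) and lower numbers for less inhibition:
compound 1 `Cc1nn(-c2ccccc2)c(Oc2ccc(Cl)cc2)c1/C=N/OCc1ccc(C(=O)OC(C)(C)C)cc1` — -9.9%
compound 2 `CCOC(=O)c1ccc(CO/N=C/c2c(C)nn(C)c2Oc2ccc(Cl)cc2)cc1` — 20.9%

Compound 2 holds the higher of the two numbers in this assay; compound 1 sits below it by a gap beyond the usual scatter. Within the data shown here, the two differ in more than one place, so no single-point step between them is available, and the gap can only be read as what the two values show.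

Compound 3 `CCOC(=O)c1ccc(CO/N=C/c2c(C)nn(-c3ccccc3)c2Oc2ccc(Cl)cc2)cc1` is not yet measured. It keeps the ethyl ester of compound 2 and differs from it in one place: phenyl in place of methyl on an aromatic nitrogen. Compound 1 carries the same phenyl on the same aromatic nitrogen, together with a different ester, and gives -9.9%, the lower of the two measured values. On that basis a downward step is expected for compound 3 relative to compound 2, of a size that may not clear the scatter, a number 15.9 percentage points lower from compound 2 to compound 3 (beyond the scatter). The estimate for compound 3 in this assay is 5%, within -15% to 25%.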

Compound 3, a percentage reported as inhibition, at one concentration (the size of the read-out at that concentration, not a potency): -17.8%
For compound 3 the middle estimate is 22.8 percentage points above the measured one; the measured number lies below the stated range.
By their numbers in this assay, from the lowest: compounds 3 and 1 (each within the scatter of the next); then compound 2.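

In this assay, among these compounds, phenyl in place of methyl on an aromatic nitrogen gives the first single-change reading at this position: a number 38.7 percentage points lower from compound 2 to compound 3 (beyond the scatter), a large step that shows the position is not indifferent to what it carries, at least with the ethyl ester in place. With phenyl held on that nitrogen, ethyl in place of tert-butyl on an oxygen next to a carbonyl group reads a number 7.9 percentage points lower from compound 1 to compound 3 (within the scatter), so the ester change does not separate the two phenyl compounds at this one concentration. Nothing on hand speaks to the reason for the large phenyl step.

Going by these compounds, it remains open whether the step belongs to phenyl alone or also appears with other groups on the same nitrogen, such as ethyl, benzyl or a pyridyl ring. On these data alone, it is also open whether the ester matters more when methyl sits on that nitrogen, as with a tert-butyl ester on the methyl compound, and what a carboxylic acid or an amide would do in place of the ester.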